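The source may hold more compounds than are shown below. What is called first, only, known or untested is meant among the compounds shown, and "the series" means these compounds.

Measured so far in a functional assay (aorta) for inhibition, with Rattus norvegicus as the target; a lower number here means that less compound is needed, a higher number that more compound is needed for the effect:
- compound 1 `O=C1C(Nc2cc(F)cc(F)c2)=CC(=O)c2ncccc21` gives 449 nM
- compound 2 `O=C1C=C(Nc2cccc(F)c2)C(=O)c2cnccc21` gives 562 nM
- compound 3 `O=C1C=C(Nc2ccc(F)c(F)c2)C(=O)c2cnccc21` gives 640 nM

In this assay, compound 3 gives 640 nM. This value lies within the usual scatter of the values for compound 1 and compound 2, so the three compounds cannot be told apart on these numbers.

The next compound is compound 4 `O=C1C=C(Nc2ccc(F)c(F)c2F)C(=O)c2cnccc21`. Its structural change from compound 3 is fluoro in place of hydrogen on an aromatic carbon. A fluoro group takes the place of hydrogen on an aromatic carbon of the same six-membered ring. This carbon is ortho to a fluoro group, ortho to a large group and meta to a fluoro group.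

Among the measured compounds shown here, only one measured step is of the same kind, a 1.1-fold higher number from compound 2 to compound 3 (0.06 log units; within the scatter), and it stays within the scatter. For the measured compounds named here, that single step is thin evidence, and no measured compound shows this replacement at this particular place. Even so, it gives no reason to expect a real shift, in either direction.

The estimated change is a 1.1-fold higher number from compound 3 to compound 4 (0.04 log units; within the scatter), which means no expected step beyond the scatter. For compound 4 the expected value is 700 nM, with an estimated range from 300 nM to 1600 nM.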

Compound 4, half-maximal effective concentration: 1130 nM
Compound 4: the middle estimate sits 1.6-fold (0.21 log units) below what was measured, within the range that was stated.
By their numbers in this assay, from the lowest: compounds 1, 2, 3 and 4 (each within the scatter of the next, the first and the last beyond it).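

At this position, a carbon of the aromatic ring that is ortho to a fluoro group, ortho to a large group and meta to a fluoro group, hydrogen can give way to fluoro without a change that can be told from ordinary assay variation: in this assay, the result is a 1.8-fold higher number from compound 3 to compound 4 (0.25 log units; within the scatter). Taken with a 1.1-fold higher number from compound 2 to compound 3 (0.06 log units; within the scatter), this makes two fluoro-for-hydrogen steps on this ring, at different places, and neither goes beyond the scatter, so compound 2, compound 3 and compound 4 show no real effect of adding fluoro atoms to the ring. Nothing available here offers an explanation for the number seen with compound 4.

What remains open is whether this position responds at all to a group other than fluoro, such as chloro, methoxy or an amine, since fluoro is the only replacement for hydrogen shown here. It is also unclear whether a repeat measurement of compound 3 and compound 4 would keep them this close, as a single step at one position is slender evidence.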